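This account rests on a few compounds, and the source may have more. Where it says the series, first, only, none or still open, it means among the compounds named here.

Measured so far:
Compound 1, `O=C(Nc1cccc(N2CCCC2=O)c1)C1CCCN(C(=O)c2cc(C(F)(F)F)cc(C(F)(F)F)c2)C1`: 0%
Compound 2, `COc1cccc(C(=O)N2CCCC(C(=O)Nc3ccc(Cl)cc3)C2)c1`: 0%

In an ADME assay on PC-3 cells (Homo sapiens) for cytotoxicity, read by WST assay, tested at 100 uM (a higher number here means more inhibition at the concentration tested (going by the name of the read-out), a lower number less inhibition), compound 1 gives 0%. Compound 2 gives 0% in this assay, and the two values stand level with each other within the scatter, so the numbers show no order between them. Compound 3, `O=C(Nc1ccc(Cl)cn1)C1CCCN(C(=O)c2cc(C(F)(F)F)cc(C(F)(F)F)c2)C1`, has not been measured in this assay. It differs from compound 1 in one place: 5-chloropyridin-2-yl in place of 3-(2-oxopyrrolidin-1-yl)phenyl on an amide-type nitrogen. Among the compounds with values here, no measured pair spans this change, so no step for it is known from the data. Because compound 1 gives 0% and compound 2 with a different amide substituent gives 0%, nothing in the measurements so far points toward inhibition at the tested concentration. The step is therefore expected to be none beyond the scatter, a number 2 percentage points higher from compound 1 to compound 3 (within the scatter). The estimate for compound 3 in this assay is 2%, with a range from -8% to 15%.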

Compound 3, a percentage reported as inhibition, at one concentration (the size of the read-out at that concentration, not a potency): 0%
For compound 3 the middle estimate is 2 percentage points above the measured one, within the range that was stated.
By their numbers in this assay, from the lowest: compounds 1, 2 and 3 (each within the scatter of the next).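

In this assay, within the data shown here, the exchange of 3-(2-oxopyrrolidin-1-yl)phenyl for 5-chloropyridin-2-yl on the amide-type nitrogen gives no change at the digits printed from compound 1 to compound 3 (within the scatter) and is the first step that can be read at this position. It shows that this position can lose the five-membered non-aromatic ring and gain a pyridine nitrogen and a chlorine without any difference in the read-out at the tested concentration. Nothing measured here offers an explanation for this result.

With all three compounds level, the compounds shown do not reveal whether any group at this position can move the read-out at all. Going by these compounds, whether a group carrying an amine or a carboxylic acid on this amide-type nitrogen would give a different reading remains open.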